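Chloro for sulfanyl on a nucleoside with values at a limit

The compounds below may be only part of what the source reports. "The series", "measured", "known", "first", "only" and "open" are said of these compounds alone.

Measured compounds in a functional assay on HEp-2 cells (Homo sapiens) for cytotoxicity; on this read-out higher numbers stand for an effect only at larger amounts of compound and lower numbers for an effect already at smaller amounts:
compound 1 `CC(=O)Nc1cc(Cl)c2nc[nH]c2n1` gives > 22 ug/mL, a limit of the assay.
compound 2 `CSc1cc(N)nc2c1ncn2[C@@H]1O[C@H](CO)[C@@H](O)[C@H]1O` gives > 22 ug/mL, a limit of the assay.
compound 3 `Nc1cc(S)c2ncn([C@@H]3O[C@H](CO)[C@@H](O)[C@H]3O)c2n1` gives > 22 ug/mL, a limit of the assay.

Compound 3 stands at the limit of this assay, as do the two other compounds, which is summarised by the limit of > 22 ug/mL in this assay, at which 3 of the 3 values shown sit. Going by the values given here, the one change among the measured compounds, a step that the two limits leave unreadable from compound 2 to compound 3, cannot be read, since both ends are limits and no number is known for either.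

Compound 4 `Nc1cc(Cl)c2ncn([C@@H]3O[C@H](CO)[C@@H](O)[C@H]3O)c2n1` differs from compound 3 by chloro in place of sulfanyl on an aromatic carbon. Among the compounds with values here, no measured step bears on this change in a readable way, and every value in this assay sits at the limit. Nothing in the data points to a step beyond the scatter, so the expectation for compound 4 is no readable change, a number no higher from compound 3 to compound 4 (the limit leaves the size open), with the estimate resting on the limit of compound 3, > 22 ug/mL. Compound 4 is therefore expected near 22 ug/mL, within a range from 8 ug/mL to 60 ug/mL, and most likely again reported only as a limit.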

Compound 4, concentration for half-maximal effect: > 22 ug/mL
Compound 4 gave a limit, no number; the forecaster's own chance of this, stated with the estimate: 70%; the middle value lies on the limit itself.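

Compound 4 gives > 22 ug/mL in this assay and this value is a limit of the assay. Going by these compounds alone, no step among compound 2, compound 3 and compound 4 can be read, since all of them sit at one limit: the limit of > 22 ug/mL in this assay, at which 4 of the 4 values shown sit. The compounds shown leave open whether chloro, sulfanyl or methylsulfanyl on the shared core makes any difference to cytotoxicity.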